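Methoxy in Place of Methyl on the Amide Nitrogen

This account rests on a few compounds, and the source may have more. Where it says the series, first, only, none or still open, it means among the compounds named here.

Compound 1: `O=C1O[C@@H](CO)CN1c1ccc(-n2cc(-c3ccccn3)cn2)c(F)c1` — 1.67
Compound 2: `CNC(=O)[C@H]1CN(c2ccc(-n3cc(-c4ccccn4)cn3)c(F)c2)C(=O)O1` — 1.39

In a physicochemical assay for lipophilicity, read by HPLC, measured as octanol-water partition (a higher number here means a more lipophilic compound, a lower number a more polar compound), compound 2 gives 1.39, while compound 1 gives 1.67. For the measured compounds named here, the single known step, a number 0.28 log units lower from compound 1 to compound 2 (within the scatter), swaps the group on a saturated ring carbon and leaves the two values within the scatter of each other, so neither compound can be called the more polar one.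

Compound 3 is `CONC(=O)[C@H]1CN(c2ccc(-n3cc(-c4ccccn4)cn3)c(F)c2)C(=O)O1`. It differs from compound 2 by methoxy in place of methyl on an amide-type nitrogen. Going by the values given here, no measured step touches this amide nitrogen, so the known data give no direct guide; the step of a number 0.28 log units lower from compound 1 to compound 2 (within the scatter) concerns a different part of the molecule. A change this small, adding one oxygen, is expected to move the partition coefficient only slightly, if at all, with a mild lean toward the polar side. Compound 3 is therefore estimated at 1.2, with a range from 0.8 to 1.6. That estimate corresponds to an expected step of a number 0.19 log units lower from compound 2 to compound 3 (within the scatter), within the scatter.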

Compound 3, partition coefficient: >= 1.58
Compound 3 ended at the assay's limit; the forecaster's own chance of this, stated with the estimate: 0%; at least 0.38 log units between middle value and limit.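

In this assay, putting methoxy in place of methyl on the amide-type nitrogen gives compound 3 a reading that is a limit and not a number: the limit of >= 1.58 in this assay, at which 1 of the 3 values shown sits.

For the compounds shown here, this is the first measured change at this nitrogen, since the step from the earlier compounds concerned a saturated ring carbon, and it reads a number at least 0.19 log units higher from compound 2 to compound 3 (that floor lies within the scatter). From the compounds shown here alone, only that floor is known, so the true size of the change remains unknown, and the step that links the other earlier compound to compound 3 cannot be read at all.

Still open, going by these compounds, is where compound 3 truly lies beyond its limit. Also open, on these data alone, is whether a longer chain such as ethoxy, or a hydroxy group, on the same amide-type nitrogen would give a readable number in this assay.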